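This account rests on a few compounds, and the source may have more. Where it says the series, first, only, none or still open, it means among the compounds named here.

Of the compounds shown here, three have so far been measured in an assay on isolated protein for binding affinity to Equilibrative nucleoside transporter 1 (Homo sapiens); on this read-out lower numbers stand for stronger inhibition and higher numbers for weaker inhibition. Compound 1 `Cc1cccc(CSc2ncnc3c2ncn3[C@@H]2O[C@H](CO)[C@@H](O)[C@H]2O)c1` gives 12000 nM, compound 2 `CCCCn1cnc2c(SC(C)C)nc(N)nc21` gives 120000 nM, and compound 3 `OC[C@H]1O[C@@H](n2cnc3c(CSc4ccccc4Cl)ncnc32)[C@H](O)[C@@H]1O` gives 1780 nM. Compound 3 thus stands lowest of the three numbers, with compound 1 nearest to it and compound 2 furthest away. Among the measured compounds shown here, the single step between compounds that differ in one place is a 6.7-fold lower number from compound 1 to compound 3 (0.83 log units; beyond the scatter).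

Compound 4 `OC[C@H]1O[C@@H](n2cnc3c(CSc4ccc(F)cc4)ncnc32)[C@H](O)[C@@H]1O` has not yet been measured. It differs from compound 3 in one place: 4-fluorophenyl in place of 2-chlorophenyl on a sulfur. For the measured compounds named here, no measured step bears directly on this change. Going by the values given here, the one known step replaces the whole sulfur-bearing group, so it says little about exchanging one halogen-bearing phenyl for another, and the data give no guide to the direction of such a swap. For compound 4 the expected step is a 1.4-fold higher number from compound 3 to compound 4 (0.15 log units; within the scatter), of a size no larger than the usual scatter. Compound 4 is therefore expected to give about 2500 nM in this assay, with a range from 800 nM to 8000 nM.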

Compound 4, half-maximal inhibitory concentration: 158 nM
Estimate against measurement, compound 4: 16-fold (1.20 log units) above; the whole stated range lies above it.
By their numbers in this assay, from the lowest: compound 4; then compound 3; then compound 1; then compound 2.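

In this assay, among the compounds shown here, the aryl group on the sulfur proves far more influential than the single earlier step could show: 4-fluorophenyl in place of 2-chlorophenyl gives an 11-fold lower number from compound 3 to compound 4 (1.05 log units; beyond the scatter), even though both groups count the same heavy atoms and neither carries a hydrogen-bond donor or acceptor. Measured against the (3-methylbenzyl)sulfanyl group, the ((4-fluorophenyl)sulfanyl)methyl group gives a 76-fold lower number from compound 1 to compound 4 (1.88 log units; beyond the scatter), the largest step among those shown. Nothing available here explains why this exchange has so large an effect.

The exchange alters the halogen and its ring position together, so the compounds shown cannot separate the two, and neither 4-chlorophenyl nor 2-fluorophenyl is among them to do so. They also leave open how a 4-methoxyphenyl or 4-aminophenyl group would behave on the same sulfur.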